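The source may hold more compounds than are shown below. What is called first, only, known or untested is meant among the compounds shown, and "the series" means these compounds.

Working notes on the series. Within the data shown here, in a functional assay on WM 266-4 cells (Homo sapiens) for antiproliferative activity, read by MTT assay, with a stated time of 24 h (a lower number here means a stronger inhibitor of growth, a higher number a weaker inhibitor of growth), compound 2 `Fc1ccccc1C1CC(c2ccc3c(c2)OCCO3)=NN1c1ccccc1` gives 9120 nM, the higher of the two numbers so far. Among the measured compounds shown here, the only other measured compound, compound 1 `COc1ccc(C2CC(c3ccc4c(c3)OCCO4)=NN2c2ccccc2)cc1OC`, gives 2160 nM.

Compound 3 `Fc1ccc(C2CC(c3ccc4c(c3)OCCO4)=NN2c2ccccc2)cc1` keeps the shared core and carries 4-fluorophenyl in place of 2-fluorophenyl on a saturated ring carbon.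

For the measured compounds named here, no measured step exchanges these two groups, so the data give no direct size for this change. Going by the values given here, the one step that bears on it is a 4.2-fold higher number from compound 1 to compound 2 (0.63 log units; beyond the scatter), which puts 2-fluorophenyl in place of 3,4-dimethoxyphenyl on that same ring carbon. That step is modest, though beyond the scatter, and it replaces a quite different group. A swap between two fluorophenyl groups is expected to be smaller than that.

The expected move is a 1.8-fold lower number from compound 2 to compound 3 (0.26 log units; within the scatter), a slightly lower number that stays within the scatter. For compound 3 the estimated value in this assay is 5000 nM, with an expected range of 2000 nM to 13000 nM.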

Compound 3, concentration for 50% growth inhibition: 6050 nM
Compound 3: the middle estimate sits 1.2-fold (0.08 log units) below what was measured; low and high end bracket the measured number.
By their numbers in this assay, from the lowest: compound 1; then compounds 3 and 2 (each within the scatter of the next).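

In this assay, among these compounds, exchanging 2-fluorophenyl for 4-fluorophenyl on the saturated ring carbon gives a 1.5-fold lower number from compound 2 to compound 3 (0.18 log units; within the scatter), so this pair offers the first direct reading of a change within the fluorophenyl groups, and the two cannot be told apart at this position. The gap to 3,4-dimethoxyphenyl on that carbon now rests on two fluorophenyl groups instead of one: alongside a 4.2-fold higher number from compound 1 to compound 2 (0.63 log units; beyond the scatter) stands a 2.8-fold higher number from compound 1 to compound 3 (0.45 log units; beyond the scatter), and neither fluorophenyl compound goes against this among the three compounds shown. Nothing in hand explains these numbers.

From the compounds shown here alone, it remains open whether the gap follows the two methoxy groups, the fluorine or both, a question that unsubstituted phenyl, 4-methoxyphenyl or 3-methoxyphenyl on the same carbon would help to settle. Going by these compounds, how a dimethylamino or carboxylic acid group on that aryl ring would read in this assay is equally open, as is any change to the phenyl group on the ring nitrogen, which stays the same in all three compounds.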